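A Larger Group on the Ring Nitrogen, Seen Once Before

This account rests on a few compounds, and the source may have more. Where it says the series, first, only, none or still open, it means among the compounds named here.

Three measured compounds share a single core and differ only in small ways. In a functional assay on HeLa cells (Homo sapiens) for inhibition, read by MTT assay, with a stated time of 48 h (on this read-out higher numbers stand for weaker inhibition and lower numbers for stronger inhibition), compound 1 `Cn1cc(NC(=O)c2cccc(NS(=O)(=O)c3ccccc3)c2)cn1` gives 78500 nM, compound 2 `COc1ccc(-n2cc(NC(=O)c3cccc(NS(=O)(=O)c4ccccc4)c3)cn2)cc1` gives 42200 nM, and compound 3 `Cn1cc(NC(=O)c2ccc(NS(=O)(=O)c3ccccc3)cc2)cn1` gives 92800 nM. The number for compound 3 is the highest of the three; its gap to compound 1 stays within the scatter, while its gap to compound 2 lies beyond it, so compound 3 and compound 1 cannot be told apart on this assay.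

Compound 4 `COc1ccc(-n2cc(NC(=O)c3ccc(NS(=O)(=O)c4ccccc4)cc3)cn2)cc1` differs from compound 3 in one place: 4-methoxyphenyl in place of methyl on an aromatic nitrogen. The same exchange has been measured once already, in the step of a 1.9-fold lower number from compound 1 to compound 2 (0.27 log units; within the scatter), which stayed within the scatter. Within the data shown here, a step of about that size is expected again, because a 1.9-fold lower number from compound 1 to compound 2 (0.27 log units; within the scatter) is the only guide available and it points towards a somewhat lower number.

Compound 4 is therefore expected to give about 50000 nM in this assay, with a likely range from 20000 nM to 120000 nM. This estimate means a step of a 1.9-fold lower number from compound 3 to compound 4 (0.27 log units; within the scatter), which is no larger than the usual scatter.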

Compound 4, half-maximal inhibitory concentration: 47200 nM
The estimate for compound 4 lay 1.1-fold (0.03 log units) above the measured number; low and high end bracket the measured number.
By their numbers in this assay, from the lowest: compounds 2, 4, 1 and 3 (each within the scatter of the next, the first and the last beyond it).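

In this assay, the exchange of methyl for 4-methoxyphenyl on the aromatic nitrogen now has a second reading on a different core: a 2.0-fold lower number from compound 3 to compound 4 (0.29 log units; within the scatter). Neither step lies beyond the scatter on its own, so one pair alone could say little, and what compound 4 adds is a repeat of the earlier reading. On these two cores, the size of the step does not appear to depend on which core carries the change: the same change on two cores in this assay, a 1.9-fold lower number (0.27 log units; within the scatter) from compound 1 to compound 2 and a 2.0-fold lower number (0.29 log units; within the scatter) from compound 3 to compound 4, 1.1-fold (0.02 log units) apart, within the scatter of two such steps

As far as these compounds go, only methyl and 4-methoxyphenyl appear at this position, so it remains open whether an unsubstituted phenyl would read like 4-methoxyphenyl, and how a benzyl group or a phenyl ring bearing a carboxylic acid or an amine would read. From the compounds shown here alone, whether the step would repeat on a third core also remains open.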